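Working notes: chloro for methoxy, compound 1 to compound 4

The source may report more compounds than this note shows. Statements on the series, on what has been measured and on what is new or still open speak of the compounds shown alone.

Measured so far in a functional assay on the whole organism (strain Swiss) with Mus musculus as the target, in the maximal electroshock model, with a stated time of 0.25 h, at a dose of 300 mg/kg by the intraperitoneal route; a lower number here means a weaker effect, a higher number a stronger effect of the compound at the dose given:
compound 1 `COc1cccc(N2CCN(C(=O)C(C)N3C(=O)CCC3=O)CC2)c1` — compound 1 gives 75%
compound 2 `COCC(C(=O)N1CCN(c2cccc(C(F)(F)F)c2)CC1)N1C(=O)CCC1=O` — compound 2 gives 25%
compound 3 `CCC(C(=O)N1CCN(c2cccc(C)c2)CC1)N1C(=O)CCC1=O` — compound 3 gives 100%

Compound 1 stands second highest of the three numbers. Its nearest neighbour is compound 3, which gives a number higher by an amount beyond the scatter; furthest is compound 2, lower by an amount beyond the scatter. None of these three pairs differ in a single place, so the numbers show only that the series spans a wide range in this assay, with compound 1 in the middle of it.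

Compound 4 `CC(C(=O)N1CCN(c2cccc(Cl)c2)CC1)N1C(=O)CCC1=O` is not yet measured. It differs from compound 1 in one place: chloro in place of methoxy on an aromatic carbon. For the measured compounds named here, no measured pair isolates this exchange, so there is no step to lean on. A change of one small group on the aromatic ring, with the rest of the molecule kept as in compound 1, is expected to move the read-out little; the step of a number 5 percentage points higher from compound 1 to compound 4 (within the scatter) is expected to stay within the scatter, with the direction uncertain. Compound 4 is therefore estimated at 80%, within a range of 45% to 100%.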

Compound 4, a percentage reported as activity, at one dose (the size of the read-out at that dose, not a potency): 75%
For compound 4 the middle estimate is 5 percentage points above the measured one; measured number inside the range.
By their numbers in this assay, from the lowest: compound 2; then compounds 1 and 4 (each within the scatter of the next); then compound 3.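

In this assay, the exchange of 3-methoxyphenyl for 3-chlorophenyl gives the series its first single-place comparison, and the read-out shows no change at the digits printed from compound 1 to compound 4 (within the scatter). On this aromatic carbon, meta to a large group, chloro therefore takes the place of methoxy with no visible effect on the read-out at this one dose, although the entering group has one heavy atom where the leaving group has two, and the hydrogen-bond acceptor counted for methoxy is gone. No measurement available here bears on why the read-out holds across this exchange.

For the compounds shown here, it remains open whether an amine or a carboxylic acid on the same aromatic carbon would leave the read-out equally unmoved, since chloro and methoxy are the only two groups compared at this position with the rest of the molecule held constant. From the compounds shown here alone, it is also open whether the exchange would behave the same way with a longer chain in place of the methyl group of compound 1, and a read-out at a single dose does not show whether the two compounds match in potency.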